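The compounds below may be only part of what the source reports. "The series", "measured", "known", "first", "only" and "open" are said of these compounds alone.

Compound 1, `CC1(c2ccccc2)CC(=O)N(CC(=O)N2CCOCC2)C1=O`, and compound 2, `CC1(c2ccccc2)CC(=O)N(CC(=O)N2CCN(c3cccc(C(F)(F)F)c3)CC2)C1=O`, belong to one series built on a shared core. In a functional assay on the whole organism (strain CD-1) with Mus musculus as the target, in the maximal electroshock model, with a stated time of 0.5 h (a lower number here means that less compound is needed, a higher number that more compound is needed for the effect), compound 1 gives 300 mg/kg. In this assay compound 2 gives 300 mg/kg. Compound 3, `CC1(c2ccccc2)CC(=O)N(CC(=O)N2CCN(c3ccc(Cl)cc3)CC2)C1=O`, carries a 4-chlorophenyl on the ring amine nitrogen; in this assay compound 3 gives "not active" (no number reported), so no single number stands for it. Compound 4, `COc1cccc(N2CCN(C(=O)CN3C(=O)CC(C)(c4ccccc4)C3=O)CC2)c1`, differs from compound 3 in one place: 3-methoxyphenyl in place of 4-chlorophenyl on an amine nitrogen in a ring. Within the data shown here, no measured pair shows how such a change moves the minimum effective dose, and compound 3 itself gives no number to step from. For compound 4 the expectation in this assay is therefore a dose near the level of compound 1 and compound 2, or again no number at all; the estimate for compound 4 is 300 mg/kg, within 100 mg/kg to 1000 mg/kg.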

Compound 4, minimum effective dose: "not active" (no number reported)
Compound 4: no number reported; the estimate stays without a comparison.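

Compound 3 and compound 4 both come without a number, so no step can be read between them, and no evidence at hand bears on this result. The compounds shown leave open whether 3-methoxyphenyl in place of 4-chlorophenyl moves the minimum effective dose at all.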